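Benzyloxy in place of pyrimidin-5-yl: working notes

A few compounds are considered here, and "the series" means these few. Any claim that something is new, unique, unknown or untested is made for them only; others in the source may bear on it.

Measured in an ADME assay on microsomes from liver (Rattus norvegicus) for metabolic stability; a lower number here means that the compound disappears faster, a higher number that the compound lasts longer:
- compound 1 `COc1cc(OCc2cccc(-c3ccc(OC)nc3)c2)c2cc(-c3cn4nc(OC)sc4n3)oc2c1`: 0.633 h
- compound 2 `COc1cc(OCc2cccc(-c3cncnc3)c2)c2cc(-c3cn4nc(OC)sc4n3)oc2c1`: 0.117 h

Of the pair, compound 2 stands lowest. Compound 3 `COc1cc(OCc2cccc(OCc3ccccc3)c2)c2cc(-c3cn4nc(OC)sc4n3)oc2c1` carries benzyloxy in place of pyrimidin-5-yl on an aromatic carbon, meta to a large group: benzyloxy in place of pyrimidin-5-yl on an aromatic carbon. Within the data shown here, the one measured step at this place, a 5.4-fold lower number from compound 1 to compound 2 (0.73 log units; beyond the scatter), is modest and beyond the scatter. It gives a scale for the change, though it involves a different entering group. With compound 2 at 0.117 h, a rise in this assay seems more likely than a fall. A moderate upward step is expected, a 2.1-fold higher number from compound 2 to compound 3 (0.33 log units; beyond the scatter). For compound 3 the estimated value is 0.25 h, with an expected range of 0.1 h to 0.65 h.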

Compound 3, half-life: 0.333 h
Estimate against measurement, compound 3: 1.3-fold (0.12 log units) below, within the range that was stated.
By their numbers in this assay, from the lowest: compound 2; then compounds 3 and 1 (each within the scatter of the next).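

In this assay, benzyloxy in place of pyrimidin-5-yl gives a 2.8-fold higher number from compound 2 to compound 3 (0.45 log units; beyond the scatter), so the low number of compound 2 does not extend to every group carrying a six-membered aromatic ring at this aromatic carbon. Benzyloxy in place of 6-methoxypyridin-3-yl gives a 1.9-fold lower number from compound 1 to compound 3 (0.28 log units; within the scatter), so this change separates compound 3 from compound 1 by no more than the usual scatter. Nothing available gives a reason for either step.

Still open, going by these compounds, is how an aliphatic amine or a carboxylic acid at this aromatic carbon would compare with benzyloxy in this half-life read-out.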